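Aryl-piperazine variation in a T-type calcium channel series

A few compounds are considered here, and "the series" means these few. Any claim that something is new, unique, unknown or untested is made for them only; others in the source may bear on it.

Three members of the series have been run so far. Compound 1 `CCCc1nc(-c2ccccc2)c(CNCCCN2CCN(c3ccc(OC)cc3)CC2)o1` gives 42.1% in an assay on HEK293 cells for inhibition of Voltage-dependent T-type calcium channel subunit alpha-1G (Homo sapiens), read by fluorescence, tested at 10 uM; on this read-out higher numbers stand for more inhibition at the one concentration tested (going by the name of the read-out) and lower numbers for less inhibition. Compound 2 `CCCc1nc(-c2ccccc2)c(CNCCCN2CCN(c3ccc(C(F)(F)F)cc3)CC2)o1` gives 51.6% in this assay, a change of a number 9.5 percentage points higher from compound 1 to compound 2 (within the scatter). Compound 3 `CCCc1nc(-c2ccccc2)c(CNCCCN2CCN(c3ccccc3C(F)(F)F)CC2)o1` gives 45% in this assay; it sits within the scatter of both neighbours, with a number 2.9 percentage points higher from compound 1 to compound 3 (within the scatter) and a number 6.6 percentage points lower from compound 2 to compound 3 (within the scatter).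

The next member is compound 4 `CCCc1nc(-c2ccccc2)c(CNCCCN2CCN(c3ccccc3F)CC2)o1`. Relative to compound 3 the change is fluoro in place of trifluoromethyl on an aromatic carbon. For the measured compounds named here, no measured step makes exactly this change; the nearest comparisons are the aryl variations on the piperazine nitrogen, a number 2.9 percentage points higher from compound 1 to compound 3 (within the scatter) and a number 6.6 percentage points lower from compound 2 to compound 3 (within the scatter), both within the scatter. Swapping one group for another on this ring has so far not moved this assay beyond the noise of repeat measurements, so no step beyond the scatter is expected here either, in either direction. Compound 4 is therefore estimated at 44%, in the range 30% to 58%, a step of a number 1 percentage points lower from compound 3 to compound 4 (within the scatter) that is expected to stay within the scatter.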

Compound 4, a percentage reported as inhibition, at one concentration (the size of the read-out at that concentration, not a potency): 54.4%
The estimate for compound 4 lay 10.4 percentage points below the measured number; the measured number falls inside the stated range.
By their numbers in this assay, from the lowest: compounds 1, 3, 2 and 4 (each within the scatter of the next, the first and the last beyond it).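

Fluoro in place of trifluoromethyl on this aromatic carbon, ortho to a large group, gives a number 9.4 percentage points higher from compound 3 to compound 4 (within the scatter) in this assay, and 2-fluorophenyl in place of 4-(trifluoromethyl)phenyl gives a number 2.8 percentage points higher from compound 2 to compound 4 (within the scatter), so neither change separates from the noise. For the compounds shown here, the first step beyond the scatter is a modest one, with 2-fluorophenyl in place of 4-methoxyphenyl on the amine nitrogen in a ring giving a number 12.3 percentage points higher from compound 1 to compound 4 (beyond the scatter). Nothing measured here accounts for any of these steps.

On these data alone, how a chloro, a methyl or a nitrile on the same aromatic carbon would read remains open. The single-concentration read-out also leaves open whether the separation of compound 4 from compound 1 would carry over to a potency measurement.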